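Swapping fluorine for benzyloxy on the aryl arm

The compounds below may be only part of what the source reports. "The series", "measured", "known", "first", "only" and "open" are said of these compounds alone.

Of the compounds shown here, three built on one shared core have been measured. In a functional assay on A-375 cells (Homo sapiens) for antiproliferative activity, read by MTT assay, with a stated time of 48 h (a lower number here means a stronger inhibitor of growth, a higher number a weaker inhibitor of growth), compound 1 `Fc1ccc(C2=NN(C(=S)Nc3ccccc3)C(c3ccc4c(c3)OCCO4)C2)cc1` gives 15700 nM. Compound 2 `COc1ccccc1C1=NN(C(=S)Nc2ccccc2)C(c2ccc3c(c2)OCCO3)C1` gives 20300 nM, and compound 3 `COc1cccc(C2=NN(C(=S)Nc3ccccc3)C(c3ccc4c(c3)OCCO4)C2)c1` gives 520 nM. Compound 1 thus stands second highest of the three numbers: the step of a 1.3-fold higher number from compound 1 to compound 2 (0.11 log units; within the scatter) lies within the scatter, whereas the step of a 30-fold lower number from compound 1 to compound 3 (1.48 log units; beyond the scatter) is large, and the step of a 39-fold lower number from compound 2 to compound 3 (1.59 log units; beyond the scatter) shows the same contrast.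

Compound 4 `S=C(Nc1ccccc1)N1N=C(c2ccc(OCc3ccccc3)cc2)CC1c1ccc2c(c1)OCCO2` has not yet been measured. It differs from compound 1 in one place: benzyloxy in place of fluoro on an aromatic carbon. The measured steps all alter the group on the carbon with the double bond to nitrogen, but none introduces benzyloxy, and the two changes recorded pulled in different directions, one within the scatter and one large. Because a 30-fold lower number from compound 1 to compound 3 (1.48 log units; beyond the scatter) shows that this ring can shift the number a long way, a move in either direction is possible, so only a modest downward step is expected for compound 4, carrying wide uncertainty. The expected step is a 2.0-fold lower number from compound 1 to compound 4 (0.29 log units; within the scatter). Compound 4 is therefore estimated at 8000 nM, between 1500 nM and 40000 nM.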

Compound 4, concentration for 50% growth inhibition: 350 nM
Compound 4: the middle estimate sits 23-fold (1.36 log units) above what was measured; measured number below the stated range.
By their numbers in this assay, from the lowest: compounds 4 and 3 (each within the scatter of the next); then compounds 1 and 2 (each within the scatter of the next).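

Replacing fluoro with benzyloxy gives a 45-fold lower number from compound 1 to compound 4 (1.65 log units; beyond the scatter), so a change at this single place, on an aromatic carbon para to a large group, can move the number in this assay a long way. Until now, this ring had carried only fluoro or methoxy, and these compounds gave no sign that a group of 8 heavy atoms with its own six-membered aromatic ring could go with such a low number. No measurement available here explains why the number falls.

The compounds shown leave open whether the added ring, the oxygen link or both matter. A methoxy on this same carbon, an amine link in place of the oxygen, or a longer chain between the oxygen and the ring would each help to separate these parts.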